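The source may report more compounds than this note shows. Statements on the series, on what has been measured and on what is new or still open speak of the compounds shown alone.

Measured in a functional assay on BCG823 cells (Homo sapiens) for inhibition, read by MTT assay, with a stated time of 72 h; a lower number here means a stronger inhibitor, a higher number a weaker inhibitor:
Compound 1, `CN(C(=O)NC(=O)c1c(F)cccc1F)c1nc(C(F)(F)F)c(C(=O)N/N=C/c2cccc(C(F)(F)F)c2)s1`: compound 1 gives 25.9 ug/mL.
Compound 2, `Cc1nc(N(C)C(=O)NC(=O)c2c(F)cccc2F)sc1C(=O)N/N=C/c1cccc(C(F)(F)F)c1`: compound 2 gives 32.7 ug/mL.
Compound 3, `CNc1nc(C(F)(F)F)c(C(=O)N/N=C/c2cccc(C(F)(F)F)c2)s1`: compound 3 gives > 100 ug/mL, which is a limit of the assay and not a number.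

Compound 1 holds the lowest of the two numbers shown; the nearest is compound 2, and the step of a 1.3-fold higher number from compound 1 to compound 2 (0.10 log units; within the scatter) lies within the scatter, so the two cannot be ordered. The result for compound 3 is the one recorded as the limit of > 100 ug/mL in this assay, at which 1 of the 3 values shown sits.

Compound 4, `CN(C(=O)NC(=O)c1ccc(F)c(F)c1)c1nc(C(F)(F)F)c(C(=O)N/N=C/c2cccc(C(F)(F)F)c2)s1`, differs from compound 1 by 3,4-difluorophenyl in place of 2,6-difluorophenyl on a carbonyl carbon. Among the compounds with values here, no measured step touches this part of the molecule: the only step on record, a 1.3-fold higher number from compound 1 to compound 2 (0.10 log units; within the scatter), changes the shared core and sits within the scatter, and compound 3 gives only a limit. There is thus no basis for expecting movement in this assay in either direction; the expected step of a 1.2-fold higher number from compound 1 to compound 4 (0.06 log units; within the scatter) is set at no change beyond the scatter, with wide bounds to reflect the absence of evidence. Compound 4 is estimated at 30 ug/mL, between 12 ug/mL and 80 ug/mL.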

Compound 4, half-maximal inhibitory concentration: 4.46 ug/mL
For compound 4 the middle estimate is 6.7-fold (0.83 log units) above the measured one; measured number outside the range, below it.
By their numbers in this assay, from the lowest: compound 4; then compounds 1 and 2 (each within the scatter of the next). At a limit, above all of these: compound 3.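

Within the data shown here, the aryl group on the carbonyl carbon is the first place where a change moves the number beyond the scatter in this assay: 3,4-difluorophenyl in place of 2,6-difluorophenyl gives a 5.8-fold lower number from compound 1 to compound 4 (0.76 log units; beyond the scatter), a modest step. The two groups hold the same atoms and differ only in how these are joined, whereas the earlier step, a 1.3-fold higher number from compound 1 to compound 2 (0.10 log units; within the scatter), changed the shared core and stayed within the scatter. Nothing measured here gives a cause for the new step.

On these data alone, whether the step comes from leaving the 2,6-difluorophenyl group or from entering the 3,4-difluorophenyl group remains open; plain phenyl or 4-methoxyphenyl on the same carbonyl carbon would help separate the two. Also open, as far as these compounds go, is whether the step holds on the methyl-bearing core of compound 2.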